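A few compounds are considered here, and "the series" means these few. Any claim that something is new, unique, unknown or untested is made for them only; others in the source may bear on it.

Measured in a functional assay on HepG2 cells (Homo sapiens) for inhibition, read by MTT assay, with a stated time of 48 h; a higher number here means a weaker inhibitor, a lower number a stronger inhibitor:
Compound 1 `COc1ccc(-n2c(SCc3ccccc3)nnc2-c2cc(OC)c(OC)c(OC)c2)cc1`: > 60000 nM
Compound 2 `COc1cc(-c2nnc(S)n2-c2ccc(N(C)C)cc2)cc(OC)c1OC`: > 60000 nM
Compound 3 `COc1cc(-c2nnc(SC)n2-c2ccc(N(C)C)cc2)cc(OC)c1OC`: > 60000 nM

Compound 3 reads > 60000 nM, which is a limit of this assay and not a number. Among the measured compounds shown here, the values of compound 1 and compound 2 are limits too, so the series so far shows (the limit of > 60000 nM in this assay, at which 3 of the 3 values shown sit). For the measured compounds named here, no compound can yet be ranked against another.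

The next compound is compound 4 `COc1cc(-c2nnc(SCc3ccccc3)n2-c2ccc(N(C)C)cc2)cc(OC)c1OC`. It differs from compound 3 by one change: phenyl in place of hydrogen on a saturated chain carbon bound to a sulfur. This turns methylsulfanyl into benzylsulfanyl, with phenyl in place of hydrogen on a saturated chain carbon bound to a sulfur.

Two measurements bear on this change. Going by the values given here, the only measured step, a step that the two limits leave unreadable from compound 2 to compound 3, has no size that can be carried over. Compound 1, which also carries benzylsulfanyl, gives > 60000 nM, again a limit.

Neither result offers any sign of a gain in this assay, so no step beyond the usual scatter is expected, and another limit is the likeliest outcome. A real number remains possible, since limits hide how far each compound lies from measurable activity. The estimated step is a number no higher from compound 3 to compound 4 (the limit leaves the size open). The expected value for compound 4 is 60000 nM, with an estimated range of 15000 nM to 120000 nM.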

Compound 4, half-maximal inhibitory concentration: > 60000 nM
Compound 4: no number, only a limit (the forecaster's own chance of this, stated with the estimate: 65%); the middle value sits exactly at the limit.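

Compound 4 gives > 60000 nM, again a limit of this assay and not a number. Its steps from compound 1, compound 2 and compound 3 cannot be read, and the series still shows only one thing: the limit of > 60000 nM in this assay, at which 4 of the 4 values shown sit.

The compounds shown leave open how far each lies from measurable activity, and whether any of these changes matters in this assay.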